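The source may hold more compounds than are shown below. What is called first, only, known or untested is meant among the compounds shown, and "the series" means these compounds.

Measured in a functional assay on MCF7 cells (Homo sapiens) for antiproliferative activity, read by MTT assay, with a stated time of 72 h; on this read-out higher numbers stand for weaker inhibition and lower numbers for stronger inhibition:
compound 1 `COc1cc(-n2ncnc2-c2ccc(C)cc2)cc(OC)c1OC`: 540 nM
compound 2 `COc1ccc(-c2ncnn2-c2cc(OC)c(OC)c(OC)c2)cc1`: 360 nM
compound 3 `CCOc1ccc(-c2ncnn2-c2cc(OC)c(OC)c(OC)c2)cc1Cl`: 17 nM

Compound 3 has the lowest of the three numbers, beyond the scatter from both others. Compound 4 `COc1cc(-n2ncnc2-c2ccc(Cl)c(Cl)c2)cc(OC)c1OC` carries chloro in place of ethoxy on an aromatic carbon, ortho to a chloro group and para to a large group: chloro in place of ethoxy on an aromatic carbon. Within the data shown here, the only measured single-place step is a 1.5-fold lower number from compound 1 to compound 2 (0.18 log units; within the scatter), a different change that bears on this one only weakly. Among the measured compounds shown here, no measured step isolates the ethoxy group, yet only compound 3 carries it, at 17 nM. A move to a higher number, beyond the scatter, is therefore expected, with an estimated step of an 8.8-fold higher number from compound 3 to compound 4 (0.95 log units; beyond the scatter). For compound 4 the estimate in this assay is 150 nM, with an expected range of 40 nM to 500 nM.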

Compound 4, half-maximal inhibitory concentration: > 10000 nM
Compound 4 gave a limit, no number; the forecaster's own chance of this, stated with the estimate: 3%; at least 66-fold (1.82 log units) between middle value and limit.
By their numbers in this assay, from the lowest: compound 3; then compounds 2 and 1 (each within the scatter of the next). At a limit, above all of these: compound 4.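

Compound 4 gives only a limit of the assay, not a number: the limit of > 10000 nM in this assay, at which 1 of the 4 values shown sits.

With chloro in place of ethoxy, ortho to a chloro group and para to a large group, the series moves sharply (an at least 580-fold higher number from compound 3 to compound 4 (2.76 log units; beyond the scatter)), so this place is far less forgiving than the within-scatter methyl-to-methoxy change suggested. The 3,4-dichlorophenyl compound also stands clearly apart from the 4-methoxyphenyl (an at least 27-fold higher number from compound 2 to compound 4 (1.44 log units; beyond the scatter)) and 4-methylphenyl (an at least 18-fold higher number from compound 1 to compound 4 (1.26 log units; beyond the scatter)) compounds. As far as these compounds go, whether an amine, a hydroxyl or a longer alkoxy chain at this place would keep a low number remains open. From the compounds shown here alone, the part played by the chloro group in compound 3 is also open.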